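The compounds below may be only part of what the source reports. "The series", "measured", "known", "first", "only" and "open" are said of these compounds alone.

Going by the values given here, in a toxicity assay on Hepa-1c1c7 cells (Mus musculus) for inhibition (on this read-out lower numbers stand for stronger inhibition and higher numbers for weaker inhibition), compound 2 `CCCCCCCCCC(O)C#CC#CC(O)CCCCC` gives 12000 nM as the only actual number so far. Compound 1 `CCCC(O)C#CC#CC(O)C1CCCCC1` gives > 50000 nM as a limit of the assay and not a number. Compound 3 `CCCCCCCCCC(O)C#CC#CC(O)C1CCCCC1` differs from compound 2 in one place, with cyclohexyl in place of pentyl on a saturated chain carbon bound to an oxygen on a saturated carbon and a triple-bonded carbon as the counted change: cyclohexyl in place of pentyl on a saturated chain carbon bound to an oxygen on a saturated carbon and a triple-bonded carbon. Among the compounds with values here, no measured pair shows this change, so no step beyond the usual scatter is expected in this assay in either direction. The expectation therefore stays close to compound 2 at 12000 nM as its starting point. Compound 3 is estimated at 10000 nM with an expected range from 4000 nM to 30000 nM in this read-out.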

Compound 3, half-maximal inhibitory concentration: 44000 nM
The estimate for compound 3 lay 4.4-fold (0.64 log units) below the measured number, and the stated range ends below it.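

In this assay, cyclohexyl in place of pentyl gives a 3.7-fold higher number from compound 2 to compound 3 (0.56 log units; beyond the scatter), so this carbon does respond to its substituent, and here the ring weakens inhibition modestly. Hexyl in place of hydrogen on a saturated chain carbon gives an at least 1.1-fold lower number from compound 1 to compound 3 (0.05 log units; that floor lies within the scatter). That step shows little, as compound 1 carries a limit and not a number: the limit of > 50000 nM in this assay, at which 1 of the 3 values shown sits.

The compounds shown leave open whether a phenyl ring or a longer chain at this carbon would raise the number further or lower it. One pair also cannot say whether the cyclohexyl effect would hold with a different chain at the other end.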